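Swapping Trifluoroethoxy for Isopropyl on an Aryl Piperazine

A few compounds are considered here, and "the series" means these few. Any claim that something is new, unique, unknown or untested is made for them only; others in the source may bear on it.

Measured so far:
- compound 1, `CNC(=O)c1cccnc1NCCCN1CCN(c2ccccc2OC)CC1`, 3.16 nM
- compound 2, `COc1ccccc1N1CCN(CCCNc2ccc(C(=O)N(C)C)cn2)CC1`, 31.6 nM
- compound 3, `CN(C)C(=O)c1cccnc1NCCCN1CCN(c2ccccc2OCC(F)(F)F)CC1`, 15.9 nM

These three compounds were tested in a functional assay on aorta for antagonist activity at Alpha-1D adrenergic receptor (Rattus norvegicus); on this read-out higher numbers stand for weaker binding and lower numbers for tighter binding. Compound 3 gives 15.9 nM, which places it second highest of the three numbers. Its nearest neighbour is compound 2, and the gap between them lies within the usual scatter of repeated measurements. The furthest is compound 1, whose number is lower by a margin that goes beyond the scatter; compound 1 and compound 3 differ in more than one place, so no single change can be held responsible.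

The next compound, compound 4, `CC(C)c1ccccc1N1CCN(CCCNc2ncccc2C(=O)N(C)C)CC1`, has not yet been measured in this assay. Compared with compound 3 it carries one change: isopropyl in place of 2,2,2-trifluoroethoxy on an aromatic carbon. For the measured compounds named here, no measured pair shows this exact change, so there is no direct precedent to lean on. The step from compound 3 to compound 4 is expected to be small, a modest move toward a higher number at most, and it may well fall within the scatter: a 1.6-fold higher number from compound 3 to compound 4 (0.20 log units; within the scatter). Compound 4 is therefore estimated at 25 nM, with a plausible range from 8 nM to 80 nM.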

Compound 4, dissociation constant: 63.1 nM
For compound 4 the middle estimate is 2.5-fold (0.40 log units) below the measured one; low and high end bracket the measured number.
By their numbers in this assay, from the lowest: compound 1; then compounds 3, 2 and 4 (each within the scatter of the next, the first and the last beyond it).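

For the compounds shown here, the pair compound 3 and compound 4 is the first to isolate a single change, on an aromatic carbon ortho to a large group, and in this assay it gives a 4.0-fold higher number from compound 3 to compound 4 (0.60 log units; beyond the scatter). This shows that the read-out responds to what sits at this position, here a swap of 2,2,2-trifluoroethoxy, with its hydrogen-bond acceptor, for isopropyl, which has none. No available measurement of any property of these groups bears on this result, so the pair shows the size of the step and offers no explanation for it.

Open, as far as these compounds go, is which part of the leaving group matters, as the oxygen, the fluorines and the size all change together. An ethoxy group at the same carbon would remove only the fluorines, while an isopropoxy group would restore the oxygen to the branched carbons of isopropyl.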